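Working notes: from compound 3 toward compound 4

The source may report more compounds than this note shows. Statements on the series, on what has been measured and on what is new or still open speak of the compounds shown alone.

Compound 1 `CNC(=N)Nc1nc(-c2ccc(OC)cc2)c(-c2ccc(OC)cc2)s1`: 62 nM in a functional assay with Oryctolagus cuniculus as the target; on this read-out lower numbers stand for stronger inhibition and higher numbers for weaker inhibition
Compound 2 `CC/N=C(/N)Nc1nc(-c2ccc(OC)cc2)c(-c2ccc(OC)cc2)s1`: > 100 nM in this assay, a limit of the assay
Compound 3 `COc1ccc(-c2nc(C(=O)N=C(N)N)sc2-c2ccc(OC)cc2)cc1`: > 100 nM in this assay, again only a limit

Compound 3 therefore stands at the limit, with no number of its own. Going by the values given here, the step to it from compound 1 is an at least 1.6-fold higher number from compound 1 to compound 3 (0.20 log units; that floor lies within the scatter), and the step that the two limits leave unreadable from compound 2 to compound 3; the only evidence on both is the limit of > 100 nM in this assay, at which 2 of the 3 values shown sit. Compound 4 `COc1ccc(-c2nc(C3=CCN(C)CC3)sc2-c2ccc(OC)cc2)cc1` differs from compound 3 by a group of 7 heavy atoms (6 carbon, 1 nitrogen; one six-membered non-aromatic ring with 1 hetero atom) in place of a group of 6 heavy atoms (2 carbon, 3 nitrogen, 1 oxygen; no ring), on an aromatic carbon. Among the compounds with values here, no measured step covers that change, and the two steps reaching compound 3 set only a floor, so no direction beyond the scatter can be read for this assay. Compound 4 is expected near 150 nM, within 40 nM to 600 nM. This estimate is expected to mean a step that the limit leaves unreadable from compound 3 to compound 4.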

Compound 4, half-maximal inhibitory concentration: < 10 nM
Compound 4 gave a limit, no number (the forecaster's own chance of this, stated with the estimate: 55%); middle value at least 15-fold (1.17 log units) from the limit.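

Going by these compounds alone, at the aromatic carbon next to the ring nitrogen and next to the ring sulfur, the six-membered non-aromatic ring with 1 hetero atom gives an at least 10-fold lower number from compound 3 to compound 4 (1.00 log units; beyond the scatter), the first step in this assay that reads as a gain beyond the scatter. Against the other open-chain groups, the same ring gives an at least 10-fold lower number from compound 2 to compound 4 (1.00 log units; beyond the scatter) and an at least 6.2-fold lower number from compound 1 to compound 4 (0.79 log units; beyond the scatter). All three sizes are floors, as the value of compound 4 is a limit.

Going by these compounds, how far compound 4 lies past that limit remains open. Also open, on these data alone, is whether a fully saturated piperidine ring or an open-chain amine at this position would give a similar step.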